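The source may report more compounds than this note shows. Statements on the series, on what has been measured and on what is new or still open speak of the compounds shown alone.

Measured compounds and their numbers in an ADME assay on microsomes from liver (Homo sapiens) for metabolic stability, tested at 2.5 uM; a lower number here means slower removal, a higher number faster removal of the compound:
compound 1, `COc1ccc(-c2c(S(=O)(=O)c3cccc(C#N)c3)cnc3cc(F)ccc23)cc1`: 0.92 mL/min
compound 2, `COc1cccc(-c2c(S(=O)(=O)c3cc(F)cc(F)c3)cnc3cc(F)ccc23)c1`: 1.81 mL/min
compound 3, `N#Cc1cccc(S(=O)(=O)c2cnc3cc(F)ccc3c2-c2cccc(Cl)c2)c1`: 0.99 mL/min

Compound 1 stands at the low end of these three numbers, yet none of the three is set apart from another beyond the scatter. Going by the values given here, the one counted step, a 1.1-fold higher number from compound 1 to compound 3 (0.03 log units; within the scatter), concerns the aryl group on the aromatic carbon of the shared core and is within the scatter. Compound 2 differs from compound 1 in two places at once, so its number is only set beside that of compound 1 without a counted step.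

The unmeasured compound 4, `COc1ccc(-c2c(S(=O)(=O)c3ccc(C)c(C)c3)cnc3cc(F)ccc23)cc1`, differs from compound 1 at the sulfonyl sulfur: 3,4-dimethylphenyl in place of 3-cyanophenyl on a sulfonyl sulfur. Among the compounds with values here, no measured step touches the group on the sulfonyl sulfur, so the single step available bears only indirectly; it was within the scatter, and the spread across all three measured compounds is likewise small. Nothing in the three numbers therefore points to a step beyond the scatter in this assay in either direction, and compound 4 is expected to land close to compound 1, with the expected step of a 1.4-fold higher number from compound 1 to compound 4 (0.15 log units; within the scatter). The estimate for compound 4 is 1.3 mL/min, within a range from 0.65 mL/min to 2.6 mL/min.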

Compound 4, intrinsic clearance in a liver preparation (reported as CLH), per the amount of preparation that the assay uses: 4.13 mL/min
For compound 4 the middle estimate is 3.2-fold (0.50 log units) below the measured one; measured number outside the range, above it.
By their numbers in this assay, from the lowest: compounds 1, 3 and 2 (each within the scatter of the next); then compound 4.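

Going by these compounds alone, the group on the sulfonyl sulfur matters in this assay: 3,4-dimethylphenyl in place of 3-cyanophenyl gives a 4.5-fold higher number from compound 1 to compound 4 (0.65 log units; beyond the scatter), the first counted step here to lie beyond the scatter, whereas the one earlier step, a 1.1-fold higher number from compound 1 to compound 3 (0.03 log units; within the scatter), concerned the aryl group on an aromatic carbon and stayed within it. The exchange is a narrow one in what is counted, since both groups hold the same number of heavy atoms and one six-membered aromatic ring of carbon only, while the nitrile leaves and two methyl groups enter. No accompanying measurement bears on this result, so the reason for the step remains unexplained.

Because the nitrile leaves and both methyl groups enter in a single change, the compounds shown do not separate the part played by each, which a group such as 3-methylphenyl or unsubstituted phenyl on the sulfonyl sulfur could begin to address. They also leave open whether the step would hold with 3-chlorophenyl on the aromatic carbon, and how a non-aromatic group on the sulfonyl sulfur, such as a morpholine, would fare.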